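The source may report more compounds than this note shows. Statements on the series, on what has been measured and on what is new or still open speak of the compounds shown alone.

Three compounds share one core, and they differ only in what hangs off the aromatic ring that carries the side chain. Compound 1 `CCCCCc1ccc(-c2cn(C[C@H](O)[C@H]3OC(=O)C(OCc4ccccc4)=C3OCc3ccccc3)nn2)cc1` gives 9890 nM in a functional assay on CFPAC-1 cells (Homo sapiens) for antiproliferative activity, read by MTT assay, with a stated time of 72 h; on this read-out higher numbers stand for weaker inhibition and lower numbers for stronger inhibition. Compound 2 `CCCCCCCCCCc1cn(C[C@H](O)[C@H]2OC(=O)C(OCc3ccccc3)=C2OCc2ccccc2)nn1` gives 40300 nM in this assay. Compound 3 `COc1ccc(-c2cn(C[C@H](O)[C@H]3OC(=O)C(OCc4ccccc4)=C3OCc3ccccc3)nn2)cc1` gives 26000 nM in this assay. On these numbers compound 2 stands highest: the step from compound 2 to compound 3 is a 1.6-fold lower number from compound 2 to compound 3 (0.19 log units; within the scatter), while the step of a 4.1-fold higher number from compound 1 to compound 2 (0.61 log units; beyond the scatter) is a modest rise on exchanging a flat aromatic group for a plain chain.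

Compound 4 `O=C1O[C@H]([C@@H](O)Cn2cc(CNS(=O)(=O)c3ccc(Cl)cc3F)nn2)C(OCc2ccccc2)=C1OCc1ccccc1` is not yet measured. It differs from compound 2 by ((4-chloro-2-fluorophenyl)sulfonyl)amino in place of nonyl on a saturated chain carbon bound to an aromatic carbon. Going by the values given here, only one step speaks to this change: the step of a 4.1-fold higher number from compound 1 to compound 2 (0.61 log units; beyond the scatter), which shows that swapping a chain for an aromatic group moved the number by a modest amount, here in the direction of a lower number when the aromatic group is present. The new group carries a ring again, so compound 4 is expected to show a modest fall in this assay, with the step of a 2.7-fold lower number from compound 2 to compound 4 (0.43 log units; beyond the scatter) as the expectation. Compound 4 is estimated at 15000 nM, within a range from 5000 nM to 45000 nM.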

Compound 4, half-maximal inhibitory concentration: 58200 nM
Compound 4: middle estimate off by 3.9-fold (0.59 log units), on the low side, outside the stated range (above it).
By their numbers in this assay, from the lowest: compound 1; then compounds 3, 2 and 4 (each within the scatter of the next, the first and the last beyond it).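

In this assay, putting ((4-chloro-2-fluorophenyl)sulfonyl)amino in place of nonyl gives a 1.4-fold higher number from compound 2 to compound 4 (0.16 log units; within the scatter), so the two groups cannot be told apart at this place on a saturated chain carbon bound to an aromatic carbon. A ring in the entering group is therefore not enough on its own to lower the number, and the earlier 4.1-fold higher number from compound 1 to compound 2 (0.61 log units; beyond the scatter), which concerned a different exchange on a different attachment, does not carry over to this one. Nothing shown here offers an explanation for this result.

Still open, as far as these compounds go, is whether a quite different group at this place, such as a primary amine or a carboxylic acid, would separate from these two. Also open, from the compounds shown here alone, is what a plain phenylsulfonylamino group, lacking the chlorine and the fluorine, would give.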